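This account rests on a few compounds, and the source may have more. Where it says the series, first, only, none or still open, it means among the compounds named here.

In a functional assay on CCRF-CEM cells (Homo sapiens) for antiproliferative activity, read by trypan blue exclusion, with a stated time of 72 h (on this read-out higher numbers stand for weaker inhibition and lower numbers for stronger inhibition), compound 3 (`NC(=O)NC(=O)c1ccc(F)c(NC(=O)CCl)c1`) gives > 20000 nM. On these data alone, this is a limit and not a number, so its true position remains unknown. Compound 2 (`CC(Cl)C(=O)Nc1cc(C(=O)NC(N)=O)ccc1Cl`) gives > 20000 nM, which is also a limit, and the two compounds share that limit: the limit of > 20000 nM in this assay, at which 2 of the 3 values shown sit. Compound 4 (`NC(=O)NC(=O)c1ccc(Cl)c(NC(=O)CCl)c1`) has chloro in place of fluoro on an aromatic carbon. Among the compounds with values here, no measured step makes this exact swap. Within the data shown here, the only measured step, an at least 6.8-fold higher number from compound 1 to compound 2 (0.83 log units; beyond the scatter), changes the group on the carbonyl carbon instead, so it bears on the question only indirectly. Carrying the same chloro as compound 4, compound 1 (`NC(=O)NC(=O)c1ccc(Cl)c(NC(=O)CBr)c1`) gives 2910 nM, but it has bromomethyl where compound 4 has chloromethyl. Compound 2 shows that the chloro alone does not guarantee a measurable value. A move towards stronger inhibition is therefore expected, but with little confidence, and the estimated step is an at least 2.2-fold lower number from compound 3 to compound 4 (0.34 log units; beyond the scatter). For compound 4, the estimate is 9000 nM, with an expected range from 3000 nM to 20000 nM.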

Compound 4, half-maximal inhibitory concentration: 15900 nM
Compound 4: middle estimate off by 1.8-fold (0.25 log units), on the low side; the measured number falls inside the stated range.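

The swap of fluoro for chloro on the aromatic carbon now has a reading, an at least 1.2-fold lower number from compound 3 to compound 4 (0.09 log units; that floor lies within the scatter), and removing the methyl from the chain carbon has another, an at least 1.2-fold lower number from compound 2 to compound 4 (0.09 log units; that floor lies within the scatter). Both are only floors, because compound 2 and compound 3 each sit at a limit and not at a number: the limit of > 20000 nM in this assay, at which 2 of the 4 values shown sit. Within the data shown here, with the chloro on the aromatic carbon kept, the one step that can be sized lies on the chain, where chloro replaces bromo: a 5.5-fold higher number from compound 1 to compound 4 (0.74 log units; beyond the scatter).

On these data alone, the true size of the fluoro to chloro step stays open, as does whether bromo on the chain would give a measurable value with fluoro on the aromatic carbon. The compounds shown also say nothing about how an amine or a methoxy group would behave in place of that chloro.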